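The source may report more compounds than this note shows. Statements on the series, on what has been measured and on what is new or still open speak of the compounds shown alone.

Measured compounds:
- compound 1 `CCCCCc1cc(Nc2ccc(OC)cc2)cc(=O)o1`: 10.1 uM
- compound 2 `COc1ccc(Nc2cc(-c3ccc4ccccc4c3)oc(=O)c2)cc1`: 0.18 uM
- compound 3 `COc1ccccc1Nc1cc(-c2ccccc2)oc(=O)c1`: 0.35 uM

In a functional assay on KB cells (Homo sapiens) for cytotoxicity, read by MTT assay, with a stated time of 72 h (on this read-out higher numbers stand for an effect only at larger amounts of compound and lower numbers for an effect already at smaller amounts), compound 1 gives the highest number of the three. Compound 3 and compound 2 both give numbers well below it, and both gaps lie beyond the scatter; neither pair, however, differs in only one place, so no single change can be read from them.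

Compound 4 `COc1ccc(Nc2cc(C3CCCC3)oc(=O)c2)cc1` differs from compound 1 in one place: cyclopentyl in place of pentyl on an aromatic carbon. For the measured compounds named here, no measured pair shows this change. The expectation is a modest step towards a lower number, a 1.7-fold lower number from compound 1 to compound 4 (0.23 log units; within the scatter), with the expected value of compound 4 in this assay set at 6 uM, within a range from 2 uM to 20 uM.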

Compound 4, concentration for half-maximal effect: 8.38 uM
Beside the measured number, compound 4's estimate is 1.4-fold (0.15 log units) below it; the measured number falls inside the stated range.
By their numbers in this assay, from the lowest: compounds 2 and 3 (each within the scatter of the next); then compounds 4 and 1 (each within the scatter of the next).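

Replacing pentyl with cyclopentyl on this aromatic carbon, next to the ring oxygen, gives a 1.2-fold lower number from compound 1 to compound 4 (0.08 log units; within the scatter) in this assay. The earlier compounds shown here had no pair that differed only here, and this first pair shows that closing the open chain into a ring leaves the number within normal repeat variation. No available evidence bears on this result.

Still open, from the compounds shown here alone, is whether a different group at this position, such as a shorter chain, an amine or a carboxylic acid, would move the number beyond that variation.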